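The source may hold more compounds than are shown below. What is called first, only, known or untested is meant among the compounds shown, and "the series" means these compounds.

Measured compounds in a functional assay on HeLa cells (Homo sapiens) for inhibition, read by CCK-8 assay, with a stated time of 72 h, tested at 2 uM; on this read-out lower numbers stand for less inhibition of growth and higher numbers for more inhibition of growth at the one concentration tested:
Compound 1 `COc1ccc(SCc2ccc(/C=C/C(=O)Nc3ccccc3N)cc2)cc1OC` gives 10.1%.
Compound 2 `Cc1ccc(SCc2ccc(C(=O)Nc3ccccc3N)cc2)cc1` gives 33.8%.
Compound 3 `Nc1ccccc1NC(=O)/C=C/c1ccc(CSc2cccc3ccccc23)cc1` gives 20.6%.

Compound 2 stands highest of the three numbers in this assay; its nearest neighbour is compound 3 and its furthest is compound 1, and both gaps lie beyond the usual scatter. Compound 4 `CCc1ccc(SCc2ccc(C(=O)Nc3ccccc3N)cc2)cc1` differs from compound 2 in one place: methyl in place of hydrogen on a saturated chain carbon bound to an aromatic carbon. Within the data shown here, only one measured step changes a single place, and it concerns a different part of the molecule: a number 10.5 percentage points higher from compound 1 to compound 3 (beyond the scatter) exchanges the whole group on the sulfur, and it stands between two compounds whose remaining structure is not that of compound 2. Among the measured compounds shown here, no measured pair compares methyl against ethyl on the group bound to the sulfur, so nothing here shows that such a change moves this read-out. The expected step in this assay is therefore a number 0.2 percentage points higher from compound 2 to compound 4 (within the scatter), none beyond the scatter. The estimated value for compound 4 is 34%, with a range from 20% to 48%.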

Compound 4, percent growth inhibition at one concentration: 30.8%
Beside the measured number, compound 4's estimate is 3.2 percentage points above it; low and high end bracket the measured number.
By their numbers in this assay, from the lowest: compound 1; then compound 3; then compounds 4 and 2 (each within the scatter of the next).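

In this assay, among these compounds, this pair gives the first direct look at the group on the sulfur with the rest of the molecule held fixed: lengthening 4-methylphenyl to 4-ethylphenyl gives a number 3 percentage points lower from compound 2 to compound 4 (within the scatter) and so does not separate the two groups. At this position, then, one added carbon leaves the read-out within its usual noise, whereas the earlier step exchanged the whole group on the sulfur in compounds with a different core. Nothing at hand offers an explanation for this outcome.

On these data alone, whether a propyl or longer chain, an amine or a carboxylic acid at the same place would move the read-out remains open. So does whether methyl to ethyl would read the same on the core of compound 1, or at other concentrations.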